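This account rests on a few compounds, and the source may have more. Where it says the series, first, only, none or still open, it means among the compounds named here.

Measured compounds in this series:
Compound 1, `CC(C)(C)c1cn(CCNc2nonc2/C(=N/O)Nc2ccc(F)c(Br)c2)nn1`, gives 132 nM.
Compound 2, `OCCc1cn(CCNc2nonc2/C(=N/O)Nc2ccc(F)c(Br)c2)nn1`, gives 247 nM.
Compound 3, `OCCCCc1cn(CCNc2nonc2/C(=N/O)Nc2ccc(F)c(Br)c2)nn1`, gives 80 nM.

All three numbers come from an assay on isolated protein for inhibition of Indoleamine 2,3-dioxygenase 1 (Homo sapiens); a lower number here means a stronger inhibitor, a higher number a weaker inhibitor. Compound 1 sits between the other two, but it cannot be set apart from either of them: the step of a 1.7-fold lower number from compound 1 to compound 3 (0.22 log units; within the scatter) and the step of a 1.9-fold higher number from compound 1 to compound 2 (0.27 log units; within the scatter) both stay within the scatter. For the measured compounds named here, the only step that reaches beyond the scatter is a 3.1-fold lower number from compound 2 to compound 3 (0.49 log units; beyond the scatter), a modest one.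

Compound 4, `CCC(O)c1cn(CCNc2nonc2/C(=N/O)Nc2ccc(F)c(Br)c2)nn1`, has not yet been measured. It differs from compound 1 in one place: 1-hydroxypropyl in place of tert-butyl on an aromatic carbon. The two measured steps that bear on this change both replace the tert-butyl group with a hydroxy-bearing chain, and neither moved the number beyond the scatter. On that basis compound 4 is expected to stay close to compound 1, with no step beyond the scatter: a 1.1-fold higher number from compound 1 to compound 4 (0.03 log units; within the scatter). The estimate for compound 4 in this assay is 140 nM, with a range from 60 nM to 330 nM.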

Compound 4, half-maximal inhibitory concentration: 73 nM
Beside the measured number, compound 4's estimate is 1.9-fold (0.28 log units) above it; measured number inside the range.
By their numbers in this assay, from the lowest: compounds 4, 3, 1 and 2 (each within the scatter of the next, the first and the last beyond it).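

In this assay, replacing tert-butyl with 1-hydroxypropyl on this aromatic carbon gives a 1.8-fold lower number from compound 1 to compound 4 (0.26 log units; within the scatter), so a hydroxy group carried on the carbon attached to the ring is tolerated here as well as those further out along the chain. Against the longer hydroxy-bearing chain the result is a 1.1-fold lower number from compound 3 to compound 4 (0.04 log units; within the scatter), which leaves 1-hydroxypropyl and 4-hydroxybutyl indistinguishable. Compound 2 is now set apart from two compounds, by a 3.4-fold lower number from compound 2 to compound 4 (0.53 log units; beyond the scatter) as well as by a 3.1-fold lower number from compound 2 to compound 3 (0.49 log units; beyond the scatter), though it remains within the scatter of compound 1.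

Nothing available here explains these steps.

Still open, going by these compounds, is how an amine, a carboxylic acid or a plain propyl chain would behave at this position. Also open, on these data alone, is whether the two mirror-image forms of the 1-hydroxypropyl group differ.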